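Extending the Crotonamide Chain of Compound 1 with a Piperidine

A few compounds are considered here, and "the series" means these few. Any claim that something is new, unique, unknown or untested is made for them only; others in the source may bear on it.

Measured compounds:
compound 1, `C/C=C/C(=O)Nc1cc2c(N3CCc4ccccc43)ncnc2cc1O[C@@H]1CCOC1`: 2610 nM
compound 2, `C/C=C/C(=O)Nc1cc2c(N3CCCc4ccccc43)ncnc2cc1O[C@@H]1CCOC1`: 10800 nM
compound 3, `COc1cc2ncnc(N3CCc4ccccc43)c2cc1NC(=O)/C=C/CN(C)C`: 2040 nM

In a functional assay on A549 cells (Homo sapiens) for antiproliferative activity, read by MTT assay, with a stated time of 72 h (a lower number here means a stronger inhibitor, a higher number a weaker inhibitor), compound 1 gives 2610 nM, the second highest of the three numbers. Its nearest neighbour is compound 3, whose value of 2040 nM lies within the scatter of compound 1; compound 3 differs from compound 1 in two places at once, so its closeness only shows that these two substitution patterns give similar numbers. Among the compounds with values here, the one single-point step in the set, a 4.1-fold higher number from compound 1 to compound 2 (0.62 log units; beyond the scatter), changed the ring system on the shared core and does not touch the chain that is altered here.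

Compound 4, `O=C(/C=C/CN1CCC(CO)CC1)Nc1cc2c(N3CCc4ccccc43)ncnc2cc1O[C@@H]1CCOC1`, differs from compound 1 by 4-(hydroxymethyl)piperidin-1-yl in place of hydrogen on a saturated chain carbon bound to a double-bonded chain carbon. Within the data shown here, no measured step bears directly on this change. Among the measured compounds shown here, the only hint is compound 3, which also carries an amine at the end of its chain and gives a number within the scatter of compound 1. The step is therefore expected to stay within the scatter, a 1.3-fold lower number from compound 1 to compound 4 (0.12 log units; within the scatter), and compound 4 is estimated at 2000 nM, between 700 nM and 6000 nM.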

Compound 4, half-maximal inhibitory concentration: 3670 nM
Compound 4: middle estimate off by 1.8-fold (0.26 log units), on the low side, and the stated range covers the measured number.
By their numbers in this assay, from the lowest: compounds 3, 1 and 4 (each within the scatter of the next); then compound 2.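

In this assay, within the data shown here, the step of a 1.4-fold higher number from compound 1 to compound 4 (0.15 log units; within the scatter) gives the first direct reading at this saturated chain carbon, as none of the earlier single-place comparisons touched the chain. Here, a hydrogen can give way to 4-(hydroxymethyl)piperidin-1-yl, with its six-membered non-aromatic ring and hydroxymethyl arm, without a change beyond the scatter in compound 4. Nothing measured here offers an explanation for this result.

From the compounds shown here alone, it remains open whether the ring and the hydroxymethyl arm each leave the number unmoved on their own, a question that an unsubstituted piperidin-1-yl or a morpholin-4-yl group at the same place could address. Going by these compounds, it is also open whether 4-(hydroxymethyl)piperidin-1-yl would behave the same way on the core of compound 2.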